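Urea to amide swap on a pyrazole series

The source may report more compounds than this note shows. Statements on the series, on what has been measured and on what is new or still open speak of the compounds shown alone.

Compound 2 `O=C(Nc1ccc(-n2cc(-c3ccncc3)c(-c3ccc(Cl)c(O)c3)n2)cc1)Nc1ccc(Cl)c(C(F)(F)F)c1` gives 1430 nM in a functional assay on M14 cells (Homo sapiens) for antiproliferative activity, read by sulforhodamine B assay, with a stated time of 48 h (on this read-out higher numbers stand for weaker inhibition and lower numbers for stronger inhibition), the lower of the two numbers recorded; compound 1 `COc1cc(-c2nn(-c3ccc(NC(=O)c4ccc(Cl)c(Cl)c4)cc3)cc2-c2ccncc2)ccc1Cl` gives 22400 nM. Compound 3 `O=C(Nc1ccc(-n2cc(-c3ccncc3)c(-c3ccc(Cl)c(O)c3)n2)cc1)c1ccc(Cl)c(Cl)c1` is not yet measured. It differs from compound 2 by 3,4-dichlorophenyl in place of (4-chloro-3-(trifluoromethyl)phenyl)amino on a carbonyl carbon. Among the compounds with values here, no measured pair shows this exact change, so its size is uncertain; compound 3 is expected to lose some ground, with the step of a 3.5-fold higher number from compound 2 to compound 3 (0.54 log units; beyond the scatter) likely beyond the scatter. Compound 3 is therefore estimated at 5000 nM, with a range from 1500 nM to 20000 nM.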

Compound 3, half-maximal inhibitory concentration: 2350 nM
Compound 3: the middle estimate sits 2.1-fold (0.33 log units) above what was measured; measured number inside the range.
By their numbers in this assay, from the lowest: compounds 2 and 3 (each within the scatter of the next); then compound 1.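

In this assay, the carbonyl carbon accepts 3,4-dichlorophenyl in place of (4-chloro-3-(trifluoromethyl)phenyl)amino with no change beyond the scatter (a 1.6-fold higher number from compound 2 to compound 3 (0.22 log units; within the scatter)), so this swap does not separate the urea compound 2 from the amide compound 3. Compound 3 also supplies a single-place comparison with compound 1, where hydrogen in place of methyl on an oxygen on an aromatic ring comes with a clear difference (a 9.5-fold lower number from compound 1 to compound 3 (0.98 log units; beyond the scatter)). No evidence at hand accounts for either step. Still open, as far as these compounds go, is whether a longer chain in place of that methyl would retain the number of compound 1 or move it toward that of compound 3. Also open, from the compounds shown here alone, is how an amine or a carboxylic acid on the amide-type carbonyl carbon would compare.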